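The compounds below may be only part of what the source reports. "The series", "measured", "known", "first", "only" and "open" are said of these compounds alone.

Series notes. Compound 1 `CCOc1ccccc1-c1ccc(-c2nc3cnccc3c(NC(C(N)=O)C3CC3)c2C#N)cc1` gives 3 in a physicochemical assay for lipophilicity, read by HPLC, at pH 7.5; on this read-out higher numbers stand for higher lipophilicity and lower numbers for lower lipophilicity. Compound 2 `CC[C@@H](Nc1c(C#N)c(-c2ccc(-c3ccccc3C(F)(F)F)cc2)nc2cnccc12)C(N)=O` gives 3.1, the second highest of the three numbers, with compound 1 within the scatter of it and compound 3 beyond it. Going by the values given here, compound 3 `CCOc1ccccc1-c1ccc(-c2nc3cnccc3c(NC(CC)CNS(=O)(=O)C3CC3)c2C#N)cc1` gives 3.6; the one measured step, a number 0.60 log units higher from compound 1 to compound 3 (beyond the scatter), concerns a change on the nitrogen on the aromatic ring of the core and so does not bear on the change examined here. Compound 4 `CC[C@@H](Nc1c(C#N)c(-c2ccc(-c3ccccc3F)cc2)nc2cnccc12)C(N)=O` differs from compound 2 by fluoro in place of trifluoromethyl on an aromatic carbon. Among the compounds with values here, no measured pair shows this change. The step is expected to read a number 0.70 log units lower from compound 2 to compound 4 (beyond the scatter), a modest fall beyond the scatter. Compound 4 is expected at 2.4, within 2 to 2.8.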

Compound 4, distribution coefficient: 2.7
Estimate against measurement, compound 4: 0.30 log units below, and the stated range covers the measured number.
By their numbers in this assay, from the lowest: compounds 4, 1 and 2 (each within the scatter of the next, the first and the last beyond it); then compound 3.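

In this assay, fluoro in place of trifluoromethyl on an aromatic carbon, ortho to a large group, now has a measured size: a number 0.40 log units lower from compound 2 to compound 4 (beyond the scatter). This position therefore responds to this change beyond the scatter, although the reading rests on a single pair. No evidence on the cause of the step is available.

Going by these compounds, a chloro, a methoxy or an amine at this position remains open. So does whether the step carries over to the side chain of compound 3.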